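Aryl ring substituent change in the isoxazole series

A few compounds are considered here, and "the series" means these few. Any claim that something is new, unique, unknown or untested is made for them only; others in the source may bear on it.

Compound 1 `COc1ccc2nc(N(Cc3cc(-c4ccc(SC(F)(F)F)cc4)no3)c3nc4ccc(F)cc4s3)sc2c1` gives 11100 nM in a functional assay on COLO 205 cells (Homo sapiens) for antiproliferative activity, read by MTT assay; a lower number here means a stronger inhibitor, a higher number a weaker inhibitor. Compound 3 `COc1cc(-c2cc(CN(c3ncccn3)c3nc4ccccc4s3)on2)cc(OC)c1OC` gives 10200 nM in this assay. Compound 2 `FC(F)(F)Oc1ccc(-c2cc(CN(c3ncccn3)c3nc4ccccc4s3)on2)cc1` gives 5690 nM in this assay, the lowest of the three numbers, yet compound 3 and compound 1 both sit within the scatter of it, so no order among the three can be read. Compound 4 `Brc1ccc(-c2cc(CN(c3ncccn3)c3nc4ccccc4s3)on2)cc1` remains unmeasured. It differs from compound 2 by bromo in place of trifluoromethoxy on an aromatic carbon. Within the data shown here, no measured pair in the set isolates this change, so the direction is open; in this assay no step beyond the scatter is expected. For compound 4 a value of 6500 nM is estimated, between 2500 nM and 17000 nM. The estimate implies a step of a 1.1-fold higher number from compound 2 to compound 4 (0.06 log units; within the scatter), expected to stay within the scatter.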

Compound 4, half-maximal inhibitory concentration: 8820 nM
Compound 4: the middle estimate sits 1.4-fold (0.13 log units) below what was measured; measured number inside the range.
By their numbers in this assay, from the lowest: compounds 2, 4, 3 and 1 (each within the scatter of the next).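

The change from 4-(trifluoromethoxy)phenyl to 4-bromophenyl gives, in this assay, a 1.6-fold higher number from compound 2 to compound 4 (0.19 log units; within the scatter). Among these compounds, this is the first step that isolates one place, and at this aromatic carbon, a bromo with one heavy atom reads the same as a trifluoromethoxy with five. No measured evidence bears on this result.

Going by these compounds, whether an amine or a carboxylic acid at this position would give a step beyond the scatter remains open. Also open, on these data alone, is whether this change reads the same on the core of compound 1.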